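This account rests on a few compounds, and the source may have more. Where it says the series, first, only, none or still open, it means among the compounds named here.

Among the measured compounds shown here, in a physicochemical assay for solubility, in phosphate buffer (on this read-out higher numbers stand for higher solubility and lower numbers for lower solubility), compound 2 (`COc1ccc2c(c1)CCc1c(-c3ccccc3)c3n(c1-2)[B-](F)(F)[N+]1=C(c2ccc(OCC(=O)O)cc2)C(I)=C(c2ccccc2)C1=N3`) gives 21800 nM, the lower of the two numbers measured so far. Compound 3 (`COc1ccc2c(c1)CCc1c(-c3ccccc3)c3n(c1-2)[B-](F)(F)[N+]1=C(c2ccc(OCC(=O)N[C@@H](CCC(=O)O)C(=O)O)cc2)C(I)=C(c2ccccc2)C1=N3`) has not yet been measured. It departs from compound 2 at one place: (1,3-dicarboxypropyl)amino in place of hydroxy on a carbonyl carbon. For the measured compounds named here, no measured pair of compounds shows this change on its own, so the expectation rests on thin evidence. Compound 2 differs in more than one place from compound 1 (`COc1ccc(C2=[N+]3C(=Nc4c(-c5ccccc5)c5c(n4[B-]3(F)F)-c3ccc(OCC(=O)N[C@@H](CC(=O)O)C(=O)O)cc3CC5)C(c3ccccc3)=C2I)cc1`), but compound 1, which also carries an amide bearing two carboxy groups, gives 165000 nM. On that single comparison, a rise beyond the scatter is expected in this assay, with an estimated 5.5-fold higher number from compound 2 to compound 3 (0.74 log units; beyond the scatter). Compound 3 is therefore expected to read about 120000 nM, within an estimated range of 40000 nM to 350000 nM.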

Compound 3, solubility: 110000 nM
Compound 3: middle estimate off by 1.1-fold (0.04 log units), on the high side; the range from low to high includes it.
By their numbers in this assay, from the lowest: compound 2; then compounds 3 and 1 (each within the scatter of the next).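

In this assay, putting (1,3-dicarboxypropyl)amino in place of hydroxy on a carbonyl carbon gives a 5.0-fold higher number from compound 2 to compound 3 (0.70 log units; beyond the scatter), so this change now has a reading of its own, beyond the scatter. Before this, the only hint came from a pair of compounds that differ in more than one place, whereas here the shared core and everything else stay the same and only this position, a carbonyl carbon whose other neighbour is a saturated chain carbon, changes. No measurement at hand accounts for the size of this step.

The compounds shown leave open whether an amide carrying a single carboxylic acid, a simple amine or a longer chain ending in two carboxy groups would read the same at this position. They also leave open how much of the step belongs to each of the two carboxy groups.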